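Removing the Terminal Phenyl from a Hydrazone

The compounds below may be only part of what the source reports. "The series", "measured", "known", "first", "only" and "open" are said of these compounds alone.

Measured so far:
Compound 1, `O=C(N/N=C/c1ccc(-c2ccccc2)cc1)c1cnccn1`, gives 57.3%.
Compound 2, `COc1ccc(/C=N/NC(=O)c2cnccn2)cc1OC`, gives 73.6%.

Both numbers come from a functional assay on the whole organism (Abdomen, strain Swiss) for inhibition, with Mus musculus as the target, with stated times of 40 min and 25 min, at a dose of 100 umol/kg by the oral route; a lower number here means less inhibition, a higher number more inhibition at the dose given (going by the name of the read-out). Of the two, compound 1 stands lowest; its nearest neighbour is compound 2, whose value lies higher by a gap beyond the usual scatter. Within the data shown here, the two compounds differ in more than one place, so no single step between them can be read.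

Compound 3, `O=C(N/N=C/c1ccccc1)c1cnccn1`, has not yet been measured. It differs from compound 1 in one place: hydrogen in place of phenyl on an aromatic carbon.

Among the measured compounds shown here, no measured pair shows what this kind of change does in this assay, so the expectation rests only on the two values above. A modest fall is expected, the step of a number 12.3 percentage points lower from compound 1 to compound 3 (beyond the scatter) being beyond the scatter but not large. Compound 3 is therefore estimated at 45%, with a range from 28% to 62%.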

Compound 3, a percentage reported as inhibition, in the whole organism at one dose (the size of the read-out at that dose, not a potency): 42.4%
Estimate against measurement, compound 3: 2.6 percentage points above; the range from low to high includes it.
By their numbers in this assay, from the lowest: compound 3; then compound 1; then compound 2.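

Replacing the phenyl with hydrogen on this aromatic carbon gives a number 14.9 percentage points lower from compound 1 to compound 3 (beyond the scatter) in this assay. Among these compounds, this is the first single change that can be read here, and it shows that the group at this position matters to the read-out. The phenyl is not essential for activity, however, since compound 3 still gives 42.4% at the dose tested. Nothing available explains the change in inhibition.

The compounds shown leave open how an amine or a carboxylic acid on this same carbon would compare with phenyl and hydrogen. Steps between compound 2 and the other two compounds cannot be read, as it differs from each of them in more than one place.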